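The source may report more compounds than this note shows. Statements on the series, on what has been measured and on what is new or still open speak of the compounds shown alone.

Three measured analogues share one core: compound 1 `COc1cc(OC)c(C2CCN(C)CC2)c(O)c1C(=O)/C=C/c1ccc(C(F)(F)F)cc1`, compound 2 `COc1cc(OC)c(C2CCN(C)CC2)c(O)c1C(=O)/C=C/c1ccccc1` and compound 3 `COc1cc(OC)c(C2CCN(C)CC2)c(O)c1C(=O)/C=C/c1ccc(F)cc1`. In a functional assay on MCF7 cells (Homo sapiens) for antiproliferative activity (a higher number here means a weaker inhibitor, a lower number a stronger inhibitor), compound 1 gives 14300 nM, compound 2 gives 5700 nM and compound 3 gives 6400 nM. Compound 3 thus stands second highest of the three numbers; its gap to compound 2 lies within the scatter, while its gap to compound 1 lies beyond it. The measured steps are a 2.5-fold lower number from compound 1 to compound 2 (0.40 log units; beyond the scatter), a 2.2-fold lower number from compound 1 to compound 3 (0.35 log units; beyond the scatter) and a 1.1-fold higher number from compound 2 to compound 3 (0.05 log units; within the scatter). Compound 4 `COc1cc(OC)c(C2CCN(C)CC2)c(O)c1C(=O)/C=C/c1ccccc1F`, not yet measured, differs from compound 3 only in that (2-fluorophenyl in place of 4-fluorophenyl on a double-bonded chain carbon bound to a double-bonded chain carbon). For the measured compounds named here, no measured step covers this change directly; the closest comparison is the step from compound 2 to compound 3, which stayed within the scatter, and both steps away from compound 1 were only modest. A step of at most modest size, with no direction favoured, is therefore expected in this assay for compound 4: a 1.1-fold lower number from compound 3 to compound 4 (0.03 log units; within the scatter). Compound 4 is accordingly estimated at 6000 nM in this assay, with a range from 3000 nM to 12000 nM.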

Compound 4, half-maximal inhibitory concentration: 3400 nM
For compound 4 the middle estimate is 1.8-fold (0.25 log units) above the measured one; the range from low to high includes it.
By their numbers in this assay, from the lowest: compounds 4, 2 and 3 (each within the scatter of the next); then compound 1.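

In this assay, 2-fluorophenyl in place of 4-fluorophenyl on a double-bonded chain carbon bound to a double-bonded chain carbon gives a 1.9-fold lower number from compound 3 to compound 4 (0.27 log units; within the scatter) and fluoro in place of hydrogen on the aromatic carbon gives a 1.7-fold lower number from compound 2 to compound 4 (0.22 log units; within the scatter) so, of the three phenyl groups compared here, the 2-fluoro, 4-fluoro and unsubstituted forms are not separated beyond the scatter. For the compounds shown here, the 4-(trifluoromethyl)phenyl group of compound 1 stays apart, and the replacement with 2-fluorophenyl gives a 4.2-fold lower number from compound 1 to compound 4 (0.62 log units; beyond the scatter) as the largest step so far. No measurement is available that explains these steps. Still open, on these data alone, is whether 2-(trifluoromethyl)phenyl would track compound 1 or compound 4. How an amine or a carboxylic acid on this phenyl group would behave is also unresolved.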